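Swapping a benzyl ester for a protected amine side chain

The source may report more compounds than this note shows. Statements on the series, on what has been measured and on what is new or still open speak of the compounds shown alone.

Measured so far:
compound 1 `O=C(CN(c1ncnc2c1ncn2C1CCCCO1)C1CC1)N[C@@H](CCC(=O)OCc1ccccc1)C(=O)OCc1ccccc1` gives 32.6%
compound 2 `O=C(O)CNC(=O)CN(c1nc(Cl)nc2[nH]cnc12)C1CC1` gives 32.2%

Both compounds were tested in a functional assay on the whole organism (Tail, strain ICR) with Mus musculus as the target, in the tail flick test, with a stated time of 30 min, at a dose of 25 umol/kg by the oral route; on this read-out lower numbers stand for a weaker effect and higher numbers for a stronger effect at the one dose given. On the two numbers available, compound 1 stands highest, but compound 2 lies only a little lower and the gap between them falls within the usual scatter, so nothing can be said about an order of the two.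

Compound 3 `CC(C)(C)OC(=O)NCCCC[C@H](NC(=O)CN(c1ncnc2c1ncn2C1CCCCO1)C1CC1)C(=O)OCc1ccccc1` has not yet been measured. It differs from compound 1 in one place: 2-((tert-butoxycarbonyl)amino)ethyl in place of benzyloxycarbonyl on a saturated chain carbon, three bonds along the chain from an amide-type nitrogen and a carbonyl carbon

Among the measured compounds shown here, no step between two measured compounds is available that would show what such a change does to the read-out, and the two measured values give no lead in either direction. The step from compound 1 to compound 3 in this assay is therefore expected to be a number 2.6 percentage points lower from compound 1 to compound 3 (within the scatter), which is no change beyond the scatter. For compound 3 an activity of 30% is estimated, within a range from 12% to 50%.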

Compound 3, a percentage reported as activity, at one dose (the size of the read-out at that dose, not a potency): 18.3%
The estimate for compound 3 lay 11.7 percentage points above the measured number; the measured number falls inside the stated range.
By their numbers in this assay, from the lowest: compound 3; then compounds 2 and 1 (each within the scatter of the next).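

Among the compounds shown here, the step in this assay gives the first reading of a single change at this position, on a saturated chain carbon, three bonds along the chain from an amide-type nitrogen and a carbonyl carbon: 2-((tert-butoxycarbonyl)amino)ethyl in place of benzyloxycarbonyl gives a number 14.3 percentage points lower from compound 1 to compound 3 (beyond the scatter) and lies beyond the scatter. The read-out therefore responds to what this position carries, even though both groups have the same heavy-atom count, and the change removes the six-membered aromatic ring of carbon only and adds a nitrogen and a hydrogen-bond donor. No measurement shown accounts for the step.

This one step cannot separate the loss of the aromatic ring from the arrival of the protected amine. As far as these compounds go, a free primary amine or a carboxylic acid at the end of the chain would help to tell these apart, and whether a longer chain is tolerated remains open.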